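From Trifluoromethyl to Methyl on the Pendant Ring

The source may hold more compounds than are shown below. What is called first, only, known or untested is meant among the compounds shown, and "the series" means these compounds.

In a functional assay on MCF7 cells (Homo sapiens) for inhibition, read by sulforhodamine B assay, with a stated time of 72 h (a lower number here means a stronger inhibitor, a higher number a weaker inhibitor), the measured compounds read as follows.
Compound 1 `CC(c1ccc(-c2ccccc2)c(F)c1)c1nnc2n1N=C(c1ccc(Cl)cc1)CS2` gives 8700 nM.
Compound 2 `CC(c1ccc(-c2ccccc2)c(F)c1)c1nnc2n1N=C(c1ccc(OC(F)(F)F)cc1)CS2` gives 4800 nM.
Compound 3 `CC(c1ccc(-c2ccccc2)c(F)c1)c1nnc2n1N=C(c1ccc(C(F)(F)F)cc1)CS2` gives 4300 nM.

Compound 3 holds the lowest number shown, though its gap to compound 2 lies within the scatter; only the step of a 2.0-fold lower number from compound 1 to compound 3 (0.31 log units; beyond the scatter) is modest and beyond it. Compound 4 `Cc1ccc(C2=Nn3c(nnc3C(C)c3ccc(-c4ccccc4)c(F)c3)SC2)cc1` differs from compound 3 by methyl in place of trifluoromethyl on an aromatic carbon. Among the compounds with values here, no measured step swaps this exact pair of groups. The nearest guides are a 2.0-fold lower number from compound 1 to compound 3 (0.31 log units; beyond the scatter) and a 1.1-fold lower number from compound 2 to compound 3 (0.05 log units; within the scatter), both small, so changes at this place have moved this assay little. A slight rise in number for compound 4 is expected: a 1.5-fold higher number from compound 3 to compound 4 (0.18 log units; within the scatter). Compound 4 is estimated at 6500 nM, within 3000 nM to 14000 nM.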

Compound 4, half-maximal inhibitory concentration: 5000 nM
For compound 4 the middle estimate is 1.3-fold (0.11 log units) above the measured one, within the range that was stated.
By their numbers in this assay, from the lowest: compounds 3, 2, 4 and 1 (each within the scatter of the next, the first and the last beyond it).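

Methyl carries no fluorine, yet at this aromatic carbon it reads level in this assay with trifluoromethyl (a 1.2-fold higher number from compound 3 to compound 4 (0.07 log units; within the scatter)) and with trifluoromethoxy (a 1.0-fold higher number from compound 2 to compound 4 (0.02 log units; within the scatter)). Its step from chloro also stays within the scatter (a 1.7-fold lower number from compound 1 to compound 4 (0.24 log units; within the scatter)), whereas the step from compound 1 to compound 3 lies just beyond it, so this position has so far tolerated these four small groups with little change. No measurement here explains why these groups read so alike.

From the compounds shown here alone, whether an amine, a carboxylic acid or a longer chain at this position would move the number remains open. So does whether any group here could bring a much larger change than these.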